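Two Hydroxyl Groups in Place of Phenyl: Expected Potency

This account rests on a few compounds, and the source may have more. Where it says the series, first, only, none or still open, it means among the compounds named here.

Compound 2 `O=C1N=C(NN2Cc3ccccc3N=C2c2ccccc2)S/C1=C/c1ccccc1` holds the lowest number among the two compounds measured in a functional assay on A549 cells (Homo sapiens) for cytotoxicity, read by MTT assay, with a stated time of 4 h (on this read-out lower numbers stand for stronger inhibition and higher numbers for weaker inhibition), where compound 2 gives 720 nM. Among the measured compounds shown here, its only neighbour, compound 1 `COc1ccc(/C=C2/SC(NN3Cc4ccccc4N=C3c3ccccc3)=NC2=O)cc1OC`, gives 44700 nM in this assay, and the step of a 62-fold lower number from compound 1 to compound 2 (1.79 log units; beyond the scatter) shows how strongly the swap of 3,4-dimethoxyphenyl for phenyl on a double-bonded chain carbon bound to a double-bonded ring carbon shifted the read-out. Compound 3 `O=C1N=C(NN2Cc3ccccc3N=C2c2ccccc2)S/C1=C/c1ccc(O)cc1O` carries a change at the same place: 2,4-dihydroxyphenyl in place of phenyl on a double-bonded chain carbon bound to a double-bonded ring carbon. For the measured compounds named here, the one step that bears on this change, a 62-fold lower number from compound 1 to compound 2 (1.79 log units; beyond the scatter), was large and ran from a substituted ring toward the bare ring; compound 3 goes back toward a substituted ring, though with hydroxyl groups rather than methoxy groups. Compound 3 is therefore expected to give a higher number than compound 2, a step estimated at a 4.2-fold higher number from compound 2 to compound 3 (0.62 log units; beyond the scatter). The estimate for compound 3 in this assay is 3000 nM, with a range from 700 nM to 15000 nM.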

Compound 3, half-maximal inhibitory concentration: 3220 nM
Compound 3: middle estimate off by 1.1-fold (0.03 log units), on the low side; measured number inside the range.
By their numbers in this assay, from the lowest: compound 2; then compound 3; then compound 1.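

In this assay, this position on a double-bonded chain carbon bound to a double-bonded ring carbon proves sensitive to which substituents the ring carries, not only to whether it carries any: 2,4-dihydroxyphenyl costs far less than 3,4-dimethoxyphenyl, with the step to the hydroxylated ring being a 4.5-fold higher number from compound 2 to compound 3 (0.65 log units; beyond the scatter) and the step between the two substituted rings being a 14-fold lower number from compound 1 to compound 3 (1.14 log units; beyond the scatter). Phenyl still gives the lowest number of the three, so neither substituted ring shown improves on the bare ring, yet the two rings differ in both group and substitution pattern, and these two changes cannot be separated here. Nothing available explains these differences.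

The compounds shown leave open how a 2,4-dimethoxyphenyl or 3,4-dihydroxyphenyl ring would read, which would separate the group from its pattern. They also leave open how a ring bearing an amine or a carboxylic acid would compare at this place.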